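Hydroxylated stilbene series: toward the hexahydroxy analogue

The source may report more compounds than this note shows. Statements on the series, on what has been measured and on what is new or still open speak of the compounds shown alone.

Working notes on three measured stilbenes and one unmeasured one. Compound 1 `Oc1ccc(/C=C/c2cc(O)c(O)c(O)c2)cc1O` holds the lowest number of the three in a functional assay; on this read-out higher numbers stand for weaker inhibition and lower numbers for stronger inhibition; compound 1 gives 3 ug/mL. Compound 3 `O=C(/C=C/c1ccc(O)c(O)c1)c1cc(O)cc(/C=C/c2ccc(O)cc2)c1` is nearest: in this assay compound 3 gives 9.2 ug/mL, a gap beyond the scatter. Compound 2 `O=C(c1cc(/C=C/c2ccc(O)cc2)cc(C(=O)c2cc(O)c(O)c(O)c2)c1)c1cc(O)c(O)c(O)c1` lies furthest: in this assay compound 2 gives 17.5 ug/mL, also beyond the scatter. Compound 4 `Oc1cc(/C=C/c2cc(O)c(O)c(O)c2)cc(O)c1O` differs from compound 1 in one place: hydroxy in place of hydrogen on an aromatic carbon. For the measured compounds named here, no measured pair shows this change, so the step has no direct precedent in the set. The step is expected to be small, a 1.2-fold lower number from compound 1 to compound 4 (0.08 log units; within the scatter), most likely none beyond the scatter or a slight move toward a lower number. Compound 4 is expected to give 2.5 ug/mL in this assay, within 1 ug/mL to 6 ug/mL.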

Compound 4, half-maximal inhibitory concentration: 0.9 ug/mL
For compound 4 the middle estimate is 2.8-fold (0.44 log units) above the measured one; the whole stated range lies above it.
By their numbers in this assay, from the lowest: compound 4; then compound 1; then compounds 3 and 2 (each within the scatter of the next).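

Hydroxy in place of hydrogen on an aromatic carbon, ortho to a hydroxy group, is the first single-place change available in this series. In this assay, it moves the number toward stronger inhibition (a 3.3-fold lower number from compound 1 to compound 4 (0.52 log units; beyond the scatter)), so this position does respond to the added hydroxy, though the step is modest. Nothing at hand accounts for the gain.

Going by these compounds, whether a methoxy group or an amine at this position would keep the lower number remains open. So does whether any other position on the core of compound 4 would respond similarly.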